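Swapping an Aminophenyl for a Dimethylphenyl Group

The source may report more compounds than this note shows. Statements on the series, on what has been measured and on what is new or still open speak of the compounds shown alone.

In an ADME assay on Huh-7 cells (Homo sapiens) for cytotoxicity (a lower number here means that less compound is tolerated, a higher number that more compound is tolerated), compound 2 `Cc1ccccc1-c1nn(-c2ccc(N)cc2)cc1CNCCN1CCN(C)CC1` reaches only the limit of the assay, > 20000 nM. Compound 1 `Cc1ccccc1CNc1nn(-c2ccc(F)cc2F)cc1CNCCN1CCN(C)CC1` likewise reports only a limit, > 20000 nM. Going by the values given here, compound 3 `CN1CCN(CCCNCc2cn(-c3ccc(C(F)(F)F)cc3)nc2-c2ccc(Cl)cc2)CC1` is the one compound with a real number, giving 2500 nM. So two of the three known values sit at the limit of > 20000 nM in this assay, at which 2 of the 3 values shown sit. Compound 4 `Cc1ccc(-n2cc(CNCCN3CCN(C)CC3)c(-c3ccccc3C)n2)c(C)c1` has not yet been tested; it differs from compound 2 in one place (2,4-dimethylphenyl in place of 4-aminophenyl on an aromatic nitrogen). Among the compounds with values here, the value of compound 2 is a limit and no step between measured compounds is known, so the size of the change is open, though the number seen for compound 3 shows that a measurable value in this range is possible. The expected step of an at least 1.6-fold lower number from compound 2 to compound 4 (0.22 log units; that floor lies within the scatter) is modest, toward less compound tolerated. Compound 4 is expected at 12000 nM, within 4000 nM to 30000 nM.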

Compound 4, half-maximal cytotoxic concentration: > 20000 nM
Compound 4 ended at the assay's limit (the forecaster's own chance of this, stated with the estimate: 40%); middle value at least 1.6-fold (0.22 log units) from the limit.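

Compound 2 and compound 4 both stop at the assay's limit, so no step between them can be read: the limit of > 20000 nM in this assay, at which 3 of the 4 values shown sit.

As far as these compounds go, how far 2,4-dimethylphenyl in place of 4-aminophenyl shifts the tolerated concentration in this assay stays open.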